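Nitro in Place of Trifluoromethyl: What Compound 4 May Give

The source may report more compounds than this note shows. Statements on the series, on what has been measured and on what is new or still open speak of the compounds shown alone.

Of the compounds shown here, three have so far been measured in a functional assay on aorta (Rattus norvegicus, strain Wistar) for inhibition, with a stated time of 60 min; a higher number here means a larger maximal response, a lower number a smaller maximal response. Compound 1 `COc1cc(-c2nc3cc([N+](=O)[O-])ccc3[nH]2)ccc1O` gives 91.7%, compound 2 `COc1cc(-c2nc3cc(C(F)(F)F)ccc3[nH]2)ccc1O` gives 99.6%, and compound 3 `CCOc1ccccc1-c1nc2cc(C(F)(F)F)ccc2[nH]1` gives 91%. Compound 1 and compound 2 share one core and differ only in nitro in place of trifluoromethyl on an aromatic carbon; that change gave a number 7.9 percentage points lower from compound 2 to compound 1 (within the scatter). Compound 3 rests on a different core; how its core differs from the core of compound 2 is not broken down here, and its maximal response sits close to both of the others.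

Compound 4 `CCOc1ccccc1-c1nc2cc([N+](=O)[O-])ccc2[nH]1` has not yet been measured. It is related to compound 3 by nitro in place of trifluoromethyl on an aromatic carbon, the same change that separates compound 2 from compound 1, made at the same place. Since the earlier step stayed within the scatter, the account expects compound 4 to stay near compound 3 as well. The step is expected to be a number 3 percentage points lower from compound 3 to compound 4 (within the scatter) because the same change earlier gave a number 7.9 percentage points lower from compound 2 to compound 1 (within the scatter). For compound 4 the expected value in this assay is therefore 88%, estimated to lie between 76% and 99%.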

Compound 4, largest response reached (Emax), in percent of the reference or control that the assay uses: 84.8%
Estimate against measurement, compound 4: 3.2 percentage points above; low and high end bracket the measured number.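

In this assay, nitro in place of trifluoromethyl on an aromatic carbon gave a number 6.2 percentage points lower from compound 3 to compound 4 (within the scatter). Set beside the earlier step, the change reads alike on the two cores: the same change on two cores in this assay, a number 7.9 percentage points lower (within the scatter) from compound 2 to compound 1 and a number 6.2 percentage points lower (within the scatter) from compound 3 to compound 4, 1.7 percentage points apart, within the scatter of two such steps On these two cores, then, the change carried over with no difference that can be told from the scatter, but this does not show that the change itself moves the maximal response, as each step alone lies within the scatter, and two cores give no rule for a third.

The compounds shown leave open how an amine or a carboxylic acid on that same aromatic carbon would compare with nitro and trifluoromethyl. They also leave open whether a step of this kind would hold on a further core or in any other assay.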